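A few compounds are considered here, and "the series" means these few. Any claim that something is new, unique, unknown or untested is made for them only; others in the source may bear on it.

Measured so far:
compound 1, `Cc1ccc(Nc2nc3nonc3nc2Nc2ccccc2F)cc1`, 2100 nM
compound 2, `COc1ccc(Nc2nc3nonc3nc2Nc2ccccc2F)cc1`, 1600 nM
compound 3, `CCOc1ccc(Nc2nc3nonc3nc2Nc2ccccc2F)cc1`, 3800 nM

In an assay on mitochondria from L6 cells (Rattus norvegicus) for activation, with a stated time of 90 min (on this read-out higher numbers stand for an effect only at larger amounts of compound and lower numbers for an effect already at smaller amounts), compound 3 stands highest of the three numbers. The steps leading to it are a 1.8-fold higher number from compound 1 to compound 3 (0.26 log units; within the scatter) and a 2.4-fold higher number from compound 2 to compound 3 (0.38 log units; beyond the scatter), so only the second sets it apart beyond the scatter, while the remaining pair, a 1.3-fold lower number from compound 1 to compound 2 (0.12 log units; within the scatter), changes nothing of note.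

Compound 4, `Fc1ccccc1Nc1nc2nonc2nc1Nc1ccc(OC(F)(F)F)cc1`, has not yet been measured. Compared with compound 3 the change is trifluoromethyl in place of ethyl on an oxygen on an aromatic ring. Among the compounds with values here, the one measured step that touches the group on this oxygen is the modest 2.4-fold higher number from compound 2 to compound 3 (0.38 log units; beyond the scatter), where lengthening the chain raised the number somewhat. Within the data shown here, no measured step exchanges carbon for fluorine, so the guide is thin. Replacing the ethyl by a group of similar bulk, with no change in donors or acceptors, is expected to leave the number near that of compound 3, with at most a small move downward, amounting to a 1.3-fold lower number from compound 3 to compound 4 (0.10 log units; within the scatter). Compound 4 is therefore estimated at 3000 nM in this assay, within a range from 1200 nM to 7500 nM.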

Compound 4, half-maximal effective concentration: 1300 nM
Compound 4: the middle estimate sits 2.3-fold (0.36 log units) above what was measured; low and high end bracket the measured number.
By their numbers in this assay, from the lowest: compounds 4, 2, 1 and 3 (each within the scatter of the next, the first and the last beyond it).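

In this assay, the group on this oxygen matters more than compound 3 alone suggested: trifluoromethyl in place of ethyl gives a 2.9-fold lower number from compound 3 to compound 4 (0.47 log units; beyond the scatter), a step beyond the scatter and downward, whereas lengthening the chain had moved the number upward. Compared with the smaller groups, the change is not distinguishable, with a 1.2-fold lower number from compound 2 to compound 4 (0.09 log units; within the scatter) and a 1.6-fold lower number from compound 1 to compound 4 (0.21 log units; within the scatter) both within the scatter, so trifluoromethoxy keeps compound 4 level with compound 1 and compound 2 despite its larger count of heavy atoms. No measurement shown explains why ethyl and trifluoromethyl differ here.

Still open, from the compounds shown here alone, is whether a longer chain such as propyl on this oxygen would raise the number further. Also unknown is how an amine or a nitrile would behave in place of these groups on the aromatic carbon.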